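A few compounds are considered here, and "the series" means these few. Any claim that something is new, unique, unknown or untested is made for them only; others in the source may bear on it.

Working notes on the series. In an ADME assay on HEK-293T cells (Homo sapiens) for inhibition, read by CCK-8 assay, with a stated time of 48 h, tested at 20 uM (a higher number here means more inhibition of growth at the concentration tested, a lower number less inhibition of growth), compound 1 (`Cc1ccc(S(=O)(=O)Oc2ccccc2/C=C(\C#N)C(=O)Nc2nnc(C)s2)cc1`) gives 35% and compound 2 (`COc1ccc(S(=O)(=O)Oc2ccccc2/C=C(\C#N)C(=O)Nc2nnc(-c3cccs3)s2)cc1`) gives 40%, so these two values lie within the scatter of each other. Compound 3 (`N#C/C(=C\c1ccccc1OS(=O)(=O)c1ccc([N+](=O)[O-])cc1)C(=O)Nc1nnc(-c2cccs2)s1`) carries nitro in place of methoxy on an aromatic carbon, para to a large group, which turns 4-methoxyphenyl into 4-nitrophenyl: nitro in place of methoxy on an aromatic carbon. Within the data shown here, no measured pair isolates this change, so no step beyond the scatter is expected in this assay, in either direction. The expected change is a number 3 percentage points higher from compound 2 to compound 3 (within the scatter). The estimate for compound 3 is 43%, with an expected range of 25% to 62%.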

Compound 3, percent growth inhibition at one concentration: 33%
Compound 3: the middle estimate sits 10 percentage points above what was measured, and the stated range covers the measured number.
By their numbers in this assay, from the lowest: compounds 3, 1 and 2 (each within the scatter of the next).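

Read in this assay and in no other test, the swap of methoxy for nitro on an aromatic carbon, para to a large group, gives a number 7 percentage points lower from compound 2 to compound 3 (within the scatter) and is the first comparison in the series that isolates one place. This read-out therefore does not separate 4-methoxyphenyl from 4-nitrophenyl at this position. No supporting measurement bears on this result.

From the compounds shown here alone, whether an amine or a carboxylic acid at this position would give a step beyond the scatter stays open. So does whether this swap gives a similar step with a methyl group in place of the thiophene-bearing substituent.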